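The compounds below may be only part of what the source reports. "The series", "measured", "known", "first", "only" and "open" are said of these compounds alone.

Compound 2 `COc1ccc(CNCCCNS(=O)(=O)c2cc(C(F)(F)F)cc(C(F)(F)F)c2)cc1OC` gives the highest number of the two measured in a functional assay on Capan-2 cells (Homo sapiens) for inhibition, read by MTT assay, with a stated time of 72 h; a lower number here means a stronger inhibitor of growth, a higher number a weaker inhibitor of growth; its nearest neighbour is compound 1 `CC(C)(C)c1ccc(CNCCCNS(=O)(=O)c2cc(C(F)(F)F)cc(C(F)(F)F)c2)cc1`, which in this assay gives 2100 nM, while compound 2 gives 15000 nM. The step from compound 2 to compound 3 `O=S(=O)(NCCCNCc1ccc(Cl)c(C(F)(F)F)c1)c1cc(C(F)(F)F)cc(C(F)(F)F)c1` is 4-chloro-3-(trifluoromethyl)phenyl in place of 3,4-dimethoxyphenyl on a saturated chain carbon bound to an amine nitrogen. Within the data shown here, only one measured step bears on it: the change a 7.1-fold higher number from compound 1 to compound 2 (0.85 log units; beyond the scatter), in which the 3,4-dimethoxyphenyl now leaving compound 2 was the group that entered. Among the measured compounds shown here, compound 3 removes that same group at the same place, so a step back toward the number of compound 1 is expected, of a size comparable to that step and in the opposite direction, although no measured compound carries 4-chloro-3-(trifluoromethyl)phenyl. On this basis compound 3 is expected to show a 5.0-fold lower number from compound 2 to compound 3 (0.70 log units; beyond the scatter) in this assay. The estimate for compound 3 is 3000 nM, with a range from 900 nM to 10000 nM.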

Compound 3, concentration for 50% growth inhibition: 9100 nM
Beside the measured number, compound 3's estimate is 3.0-fold (0.48 log units) below it; the measured number falls inside the stated range.
By their numbers in this assay, from the lowest: compound 1; then compounds 3 and 2 (each within the scatter of the next).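

Exchanging the 3,4-dimethoxyphenyl for the 4-chloro-3-(trifluoromethyl)phenyl on a saturated chain carbon bound to an amine nitrogen gives, in this assay, a 1.6-fold lower number from compound 2 to compound 3 (0.22 log units; within the scatter), so the two groups are not told apart here, although the leaving group has 2 hydrogen-bond acceptors and the entering group has none. Set against the 4-(tert-butyl)phenyl, the same entering group gives a 4.3-fold higher number from compound 1 to compound 3 (0.64 log units; beyond the scatter), which shows that the gap to compound 1 is not confined to the 3,4-dimethoxyphenyl and leaves compound 1 alone at the low end of the three. Nothing measured here explains this order.

Three aryl groups cannot show which feature of the 4-(tert-butyl)phenyl sets compound 1 apart. A plain phenyl, a 4-methylphenyl or a cyclohexyl at this place would test how much of that group is needed.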